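The source may hold more compounds than are shown below. What is called first, only, known or untested is meant among the compounds shown, and "the series" means these compounds.

Measured compounds:
- compound 1 `O=C(CCCCC1CCSS1)NCc1cn(CCCCCOc2ccc3ccc(=O)oc3c2)nn1`: 46.3%
- compound 2 `Cc1cc(=O)oc2cc(OCCCCCn3cc(CNC(=O)CCCCC4CCSS4)nn3)ccc12`: 45.6%

In a functional assay on PC-12 cells (Rattus norvegicus) for cytotoxicity, read by MTT assay, with stated times of 3 h and 2 h, tested at 0.1 uM (on this read-out higher numbers stand for a stronger effect at the one concentration tested and lower numbers for a weaker effect), compound 1 gives 46.3%. In this assay, among the compounds with values here, compound 2 gives 45.6%, and the step of a number 0.7 percentage points lower from compound 1 to compound 2 (within the scatter) keeps compound 1 and compound 2 together within the scatter, so compound 1 stands level with the only other measured compound rather than apart from it.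

Compound 3 `CCOC(=O)c1cc2ccc(OCCCCCn3cc(CNC(=O)CCCCC4CCSS4)nn3)cc2oc1=O` has not yet been measured. It differs from compound 1 by ethoxycarbonyl in place of hydrogen on an aromatic carbon. Within the data shown here, the single measured step, a number 0.7 percentage points lower from compound 1 to compound 2 (within the scatter), concerns a different group on the same shared core and shows that a change at an aromatic carbon left this assay unchanged beyond the scatter. That step bears on the present one only loosely; nothing measured here involves ethoxycarbonyl. Compound 3 is therefore expected to show a number 1.3 percentage points lower from compound 1 to compound 3 (within the scatter), with no step beyond the scatter. The estimate for compound 3 in this assay is 45%, within a range of 30% to 60%.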

Compound 3, a percentage reported as activity, at one concentration (the size of the read-out at that concentration, not a potency): 34.4%
Estimate against measurement, compound 3: 10.6 percentage points above, and the stated range covers the measured number.
By their numbers in this assay, from the lowest: compound 3; then compounds 2 and 1 (each within the scatter of the next).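

In this assay, ethoxycarbonyl in place of hydrogen on an aromatic carbon of the six-membered ring with 1 oxygen gives a number 11.9 percentage points lower from compound 1 to compound 3 (beyond the scatter), and this is the only step shown that lies beyond the scatter. The methyl step, a number 0.7 percentage points lower from compound 1 to compound 2 (within the scatter), had suggested no change, so compound 3 shows that a substituent on an aromatic carbon of the shared core can move this read-out, though the step is modest in size. Nothing measured here accounts for the step.

The compounds shown leave open whether a carboxylic acid, a primary amide or a longer butoxycarbonyl group on this same carbon would give a number like that of compound 3 or one closer to that of compound 1. They also leave open how the step would look at other concentrations, since each number comes from a single one.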